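A Second Methyl on the Shared Core

This account rests on a few compounds, and the source may have more. Where it says the series, first, only, none or still open, it means among the compounds named here.

Of the compounds shown here, three that share one ketone-linked core have been tested in a functional assay on the whole organism (strain Sprague-Dawley) for inhibition, with Rattus norvegicus as the target, read by paw edema, with stated times of 1 h and 3 h, at a dose of 50 mg/kg by the oral route; a lower number here means less inhibition, a higher number more inhibition at the dose given (going by the name of the read-out). Compound 2 `Nc1nc(-c2ccccc2)c(C(=O)c2cnc3ccccn23)s1` gives 40%. Compound 3 `Cc1ccn2c(C(=O)c3sc(N)nc3-c3ccccc3)cnc2c1`, which carries one extra methyl, gives 26%. Compound 1 `Cc1ccc2ncc(C(=O)c3sc(N)nc3N(C)C)n2c1` differs from compound 2 in two places. Compound 1 gives 23%. On these numbers compound 2 stands highest, and its distance to each of the other two lies beyond the scatter. Compound 4 `Cc1ccc2ncc(C(=O)c3sc(N)nc3-c3ccccc3)n2c1` has not yet been measured in this assay. It differs from compound 2 by methyl in place of hydrogen on an aromatic carbon. Among the measured compounds shown here, the only measured step of the same kind is a number 14 percentage points lower from compound 2 to compound 3 (beyond the scatter), with the methyl entering at a different spot on the same core; compound 1, which also carries a methyl, sits low as well, though it is not a single-change comparison. A drop of similar size is therefore expected, a number 12 percentage points lower from compound 2 to compound 4 (beyond the scatter). Compound 4 is estimated at 28%, with a likely range from 14% to 42%.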

Compound 4, a percentage reported as inhibition, in the whole organism at one dose (the size of the read-out at that dose, not a potency): 77%
Estimate against measurement, compound 4: 49 percentage points below; the whole stated range lies below it.
By their numbers in this assay, from the lowest: compounds 1 and 3 (each within the scatter of the next); then compound 2; then compound 4.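

Measured in this assay, the step of a number 37 percentage points higher from compound 2 to compound 4 (beyond the scatter) runs opposite to the step of a number 14 percentage points lower from compound 2 to compound 3 (beyond the scatter), so the same change of hydrogen to methyl on the shared core can raise or lower the inhibition, depending on which aromatic carbon carries the methyl. With the methyl held at the carbon two atoms from the ring nitrogen, the step of a number 54 percentage points higher from compound 1 to compound 4 (beyond the scatter) shows that phenyl in place of dimethylamino also matters greatly at the other site of change. Nothing measured here explains either step.

Still open, as far as these compounds go, is whether an ethyl chain, a methoxy group or an amine at this same carbon would keep the higher inhibition. Also open, from the compounds shown here alone, is how the dimethylamino compound would read with hydrogen in place of its methyl.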